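Methyl Added to the Fused Ring of Compound 1

The source may hold more compounds than are shown below. What is called first, only, known or untested is meant among the compounds shown, and "the series" means these compounds.

Compound 1 `COc1ccc(-n2ncn(Cc3cn(Cc4cc5ccccc5nc4Cl)nn3)c2=O)cc1`: 958 ug/mL
Compound 2 `O=c1n(Cc2cn(Cc3cc4ccccc4nc3Cl)nn2)cnn1-c1ccccc1`: 655 ug/mL

Within the data shown here, in an ADME assay on HEK293 cells (Homo sapiens) for cytotoxicity, read by MTT assay (a higher number here means a weaker inhibitor, a lower number a stronger inhibitor), compound 1 gives 958 ug/mL, the highest of the two numbers so far. Compound 2 gives 655 ug/mL; the step of a 1.5-fold lower number from compound 1 to compound 2 (0.17 log units; within the scatter) is within the scatter. Compound 3 `COc1ccc(-n2ncn(Cc3cn(Cc4cc5cc(C)ccc5nc4Cl)nn3)c2=O)cc1` differs from compound 1 by methyl in place of hydrogen on an aromatic carbon. Among the measured compounds shown here, the only measured step, a 1.5-fold lower number from compound 1 to compound 2 (0.17 log units; within the scatter), concerns a different change on a different ring and was within the scatter, so nothing measured points to a shift in this assay beyond the scatter here. Compound 3 is therefore expected to give about 900 ug/mL, within 450 ug/mL to 1800 ug/mL, an expected step of a 1.1-fold lower number from compound 1 to compound 3 (0.03 log units; within the scatter).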

Compound 3, half-maximal inhibitory concentration: 615 ug/mL
Estimate against measurement, compound 3: 1.5-fold (0.17 log units) above; the range from low to high includes it.
By their numbers in this assay, from the lowest: compounds 3, 2 and 1 (each within the scatter of the next).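

Among these compounds, compound 3 is the first in this set with a change on the fused ring system, and in this assay putting methyl in place of hydrogen on this aromatic carbon leaves the number within the scatter (a 1.6-fold lower number from compound 1 to compound 3 (0.19 log units; within the scatter)). This position therefore takes one added carbon with no shift that can be told apart from ordinary repeat variation. No measured evidence bears on the reason for this result.

As far as these compounds go, whether a longer chain, an amine or a carboxylic acid at this carbon would move the number beyond the scatter remains open. So does whether methyl on the other carbons of this ring would behave the same way.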